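The source may hold more compounds than are shown below. What is called first, only, known or untested is meant among the compounds shown, and "the series" means these compounds.

Measured compounds:
compound 1 `CCCCNc1nc(N)nc2c1CN(Cc1ccccc1)CC2` gives 0.06 uM in an assay on HEK293 cells for agonist activity at Toll-like receptor 8 (Homo sapiens), read by a luciferase reporter, with a stated time of 6 h; a lower number here means that less compound is needed, a higher number that more compound is needed for the effect
compound 2 `CCCCNc1nc(N)nc2c1CN(Cc1ccncc1)CC2` gives 0.29 uM in this assay
compound 3 `CCCCNc1nc(N)nc2c1CN(C(=O)c1cnccn1)CC2` gives 2.2 uM in this assay

Compound 3 stands at the highest number of the three. Its nearest neighbour is compound 2, and the gap is a 7.6-fold higher number from compound 2 to compound 3 (0.88 log units; beyond the scatter); the furthest is compound 1, with a 37-fold higher number from compound 1 to compound 3 (1.56 log units; beyond the scatter). Within the measured set, the step of a 4.8-fold higher number from compound 1 to compound 2 (0.68 log units; beyond the scatter) is the only one that swaps one aromatic group for another while the rest of the molecule is kept, and it is modest.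

Compound 4 `CCCCNc1nc(N)nc2c1CN(C(=O)c1csnn1)CC2` has not yet been measured. It differs from compound 3 in one place: 1,2,3-thiadiazol-4-yl in place of pyrazin-2-yl on a carbonyl carbon. For the measured compounds named here, no measured step exchanges one aromatic ring on the carbonyl carbon for another, so the closest guide is the aromatic swap between compound 1 and compound 2, which moved the number only modestly. The two carbonyl-bearing compounds, compound 3 and compound 4, share everything else, so a step in this assay of similar or smaller size is expected, with no firm direction; a number close to that of compound 3 is the most likely outcome.

Compound 4 is therefore expected to come out at about 2.5 uM, within 0.8 uM to 8 uM, which corresponds to an estimated step of a 1.1-fold higher number from compound 3 to compound 4 (0.06 log units; within the scatter).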

Compound 4, minimum effective concentration: 0.1 uM
For compound 4 the middle estimate is 25-fold (1.40 log units) above the measured one; measured number outside the range, below it.
By their numbers in this assay, from the lowest: compounds 1 and 4 (each within the scatter of the next); then compound 2; then compound 3.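

In (this assay), the aromatic ring on the carbonyl carbon proves to be a strong determinant of the number: 1,2,3-thiadiazol-4-yl in place of pyrazin-2-yl gives (a 22-fold lower number from compound 3 to compound 4 (1.34 log units; beyond the scatter)), a larger step than the earlier aromatic swap on a saturated chain carbon (a 4.8-fold higher number from compound 1 to compound 2 (0.68 log units; beyond the scatter)). The high number of compound 3 therefore does not hold for the carbonyl-linked compounds in general: (1,2,3-thiadiazol-4-yl)carbonyl in place of (pyridin-4-yl)methyl gives (a 2.9-fold lower number from compound 2 to compound 4 (0.46 log units; beyond the scatter)), while in place of benzyl it gives (a 1.7-fold higher number from compound 1 to compound 4 (0.22 log units; within the scatter)), a step within the scatter. The ring exchange changes ring size and the count and kind of hetero atoms together, and no measured evidence is available to explain the size of the step.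

From the compounds shown here alone, it remains open whether the five-membered ring, the sulfur or the arrangement of the hetero atoms carries the step, which thiazol-4-yl or furan-2-yl on the same carbonyl carbon could help separate. Also open, going by these compounds, is how the carbonyl contributes, which (1,2,3-thiadiazol-4-yl)methyl on the amine nitrogen in a ring would address.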